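Swapping bromine for fluorine on a hydrazone thiazoline

A few compounds are considered here, and "the series" means these few. Any claim that something is new, unique, unknown or untested is made for them only; others in the source may bear on it.

Three compounds share a core and were tested in a functional assay on C6 cells (Rattus norvegicus) for cytotoxicity, read by MTT assay, with a stated time of 24 h, tested at 50 ug/mL; a higher number here means a weaker effect of the compound at the concentration tested, a lower number a stronger effect. Compound 1, `Cc1nnc(SCC(=O)N/N=c2/scc(-c3ccccc3)n2-c2ccccc2)s1`, gives 63.9%. Compound 3, `Cc1ccc(-c2cs/c(=N/NC(=O)CSc3nncn3C)n2-c2ccccc2)cc1`, gives 53.8%. Compound 2, `O=C(CSc1nnnn1-c1ccccc1)N/N=c1/scc(-c2ccc(Br)cc2)n1-c1ccccc1`, gives 32%, the lowest of the three numbers and therefore the strongest effect, with both gaps beyond the usual scatter.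

Compound 4, `O=C(CSc1nnnn1-c1ccccc1)N/N=c1/scc(-c2ccc(F)cc2)n1-c1ccccc1`, differs from compound 2 in one place: fluoro in place of bromo on an aromatic carbon. For the measured compounds named here, no measured pair shows this exact change, so its effect is uncertain. A modest rise in the number, meaning a weaker effect, is expected, and the estimated step is a number 13 percentage points higher from compound 2 to compound 4 (beyond the scatter). In this assay compound 4 is thus expected to give about 45%, with a plausible range from 30% to 62%.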

Compound 4, a percentage reported as activity, at one concentration (the size of the read-out at that concentration, not a potency): 43.7%
Beside the measured number, compound 4's estimate is 1.3 percentage points above it, and the stated range covers the measured number.
By their numbers in this assay, from the lowest: compound 2; then compound 4; then compound 3; then compound 1.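

For the compounds shown here, this is the first comparison in the set that changes only one place: going from 4-bromophenyl to 4-fluorophenyl gives a number 11.7 percentage points higher from compound 2 to compound 4 (beyond the scatter) in this assay. The halogen at this position therefore affects the read-out, and bromo gives the stronger effect of the two. The data offer no measured explanation for this difference.

On these data alone, how chloro or an amine would behave at this position remains open. So does whether the same swap would give a similar step alongside the side chains of compound 1 or compound 3.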